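A diethylamino group on the core of compound 1

The source may report more compounds than this note shows. Statements on the series, on what has been measured and on what is new or still open speak of the compounds shown alone.

Three compounds have so far been measured in a functional assay on HCT-15 cells (Homo sapiens) for cytotoxicity, read by MTT assay, with a stated time of 2 days; on this read-out lower numbers stand for stronger inhibition and higher numbers for weaker inhibition:
Compound 1 `Cc1ccc2nc(-c3ccccc3C(F)(F)F)[nH]c(=O)c2c1` gives > 50000 nM, which is a limit of the assay and not a number.
Compound 2 `Cc1ccc2nc(-c3ccccc3OC(F)(F)F)[nH]c(=O)c2c1` gives 2790 nM.
Compound 3 `Cc1ccc2nc(-c3ccccc3C)[nH]c(=O)c2c1` gives 11700 nM.

Compound 1 thus stands at the limit (the limit of > 50000 nM in this assay, at which 1 of the 3 values shown sits), while the other two sit clearly lower, as shown by an at least 17-fold lower number from compound 1 to compound 2 (1.25 log units; beyond the scatter) and an at least 4.2-fold lower number from compound 1 to compound 3 (0.63 log units; beyond the scatter). Compound 4 `CCN(CC)c1ccc2nc(-c3ccccc3C(F)(F)F)[nH]c(=O)c2c1` differs from compound 1 by diethylamino in place of methyl on an aromatic carbon. For the measured compounds named here, every measured step changes the group on the pendant ring, none the group on the core, so no measured step bears on this change. The expectation is therefore no step beyond the scatter, estimated as an at least 1.2-fold lower number from compound 1 to compound 4 (0.09 log units; that floor lies within the scatter). Compound 4 is accordingly expected near 40000 nM, between 8000 nM and 200000 nM.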

Compound 4, half-maximal inhibitory concentration: 280 nM
For compound 4 the middle estimate is 140-fold (2.15 log units) above the measured one; measured number outside the range, below it.
By their numbers in this assay, from the lowest: compound 4; then compound 2; then compound 3. At a limit, above all of these: compound 1.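

For the compounds shown here, the group on the core, which no earlier step touched, clearly affects activity in these cells: diethylamino in place of methyl on an aromatic carbon gives an at least 170-fold lower number from compound 1 to compound 4 (2.25 log units; beyond the scatter). So changes to the core can matter as well as changes to the pendant ring. That step is only a floor because compound 1 stands at a limit of the assay: the limit of > 50000 nM in this assay, at which 1 of the 4 values shown sits.

The compounds shown leave open whether a smaller amine such as dimethylamino, or a plain ethyl chain, would act like diethylamino at this place. Going by these compounds, it also remains open whether diethylamino has a similar effect with trifluoromethoxy or methyl on the pendant ring.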